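Chloro for Methyl, Read Against Three Measured Compounds

The source may hold more compounds than are shown below. What is called first, only, known or untested is meant among the compounds shown, and "the series" means these compounds.

Compound 1 `Cc1ccc(-n2cc(C(=O)Nc3cc(F)cc(F)c3)c(=O)c3ccc(N(C)C)nc32)cc1OCCCCCCC[N+]1(C)CCN(C)CC1` gives 25% in an assay on LX2 cells for inhibition of COL1A1 promoter (Homo sapiens), read by a luciferase reporter, with a stated time of 24 h, tested at 50 uM; on this read-out higher numbers stand for a stronger effect at the one concentration tested and lower numbers for a weaker effect. Compound 2 `CN1CC[N+](C)(CCCCCCCOc2cc(-n3cc(C(=O)Nc4cc(F)cc(F)c4)c(=O)c4ccc(N(C)C)nc43)ccc2Cl)CC1` carries chloro in place of methyl on an aromatic carbon relative to compound 1, and in this assay compound 2 gives 45.2%, so that a number 20.2 percentage points higher from compound 1 to compound 2 (beyond the scatter). Compound 3 `CC[N+]1(CCCCCCCOc2cc(-n3cc(C(=O)Nc4cc(F)cc(F)c4)c(=O)c4ccc(N(C)C)nc43)ccc2C)CCCC1` differs from compound 1 by a group of 7 heavy atoms (6 carbon, 1 nitrogen; one five-membered non-aromatic ring with 1 hetero atom) in place of a group of 8 heavy atoms (6 carbon, 2 nitrogen; one six-membered non-aromatic ring with 2 hetero atoms), on a saturated chain carbon, seven bonds along the chain from an oxygen on an aromatic ring; in this assay compound 3 gives 81.4%, the highest of the three numbers, and a number 56.4 percentage points higher from compound 1 to compound 3 (beyond the scatter). Compound 4 `CC[N+]1(CCCCCCCOc2cc(-n3cc(C(=O)Nc4cc(F)cc(F)c4)c(=O)c4ccc(N(C)C)nc43)ccc2Cl)CCCC1` has not been measured. It differs from compound 3 by chloro in place of methyl on an aromatic carbon, the same change as that from compound 1 to compound 2, at a place described in identical words. That single earlier instance of the change raised the number, so the step from compound 3 to compound 4 is expected to be a number 6.6 percentage points higher from compound 3 to compound 4 (within the scatter), smaller than the earlier step because compound 3 already gives 81.4% and the read-out cannot exceed complete inhibition. On that basis compound 4 is estimated to give 88%, with a likely range from 70% to 98%.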

Compound 4, a percentage reported as inhibition, at one concentration (the size of the read-out at that concentration, not a potency): 96.4%
Estimate against measurement, compound 4: 8.4 percentage points below; the range from low to high includes it.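

In this assay, chloro in place of methyl on an aromatic carbon again raised the read-out, with a number 15 percentage points higher from compound 3 to compound 4 (beyond the scatter), and the two instances of this change agree across the two cores: the same change on two cores in this assay, a number 20.2 percentage points higher (beyond the scatter) from compound 1 to compound 2 and a number 15 percentage points higher (beyond the scatter) from compound 3 to compound 4, 5.2 percentage points apart, within the scatter of two such steps

The exchange of the ring at the end of the chain carried over in the same way, with a number 51.2 percentage points higher from compound 2 to compound 4 (beyond the scatter), and it too agrees with its earlier instance: the same change on two cores in this assay, a number 56.4 percentage points higher (beyond the scatter) from compound 1 to compound 3 and a number 51.2 percentage points higher (beyond the scatter) from compound 2 to compound 4, 5.2 percentage points apart, within the scatter of two such steps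

Among these four compounds, each change therefore kept its direction and a similar size whichever form the other place took, but two pairs in a single assay do not show that this would hold on any other core, and a read-out at one concentration says nothing of potency or of why the steps arise.

The compounds shown leave open how a fluoro, bromo or methoxy group would read in place of chloro on that aromatic carbon. They also leave open how a shorter or longer chain, or a piperidine ring at its end, would read.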